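Amide carbonyl substituent in the chalcone series

The compounds below may be only part of what the source reports. "The series", "measured", "known", "first", "only" and "open" are said of these compounds alone.

Compound 2 `COc1cc(/C=C/C(=O)c2cccc(NC(=O)C(C)C)c2)ccc1O` stands highest of the three measured in a functional assay on HUVEC cells (Homo sapiens) for inhibition, tested at 10 ug/mL (on this read-out lower numbers stand for a weaker effect and higher numbers for a stronger effect at the one concentration tested), where compound 2 gives 56%. Compound 1 `COc1cc(/C=C/C(=O)c2cccc(NC(=O)c3ccc(Cl)c(Cl)c3)c2)ccc1O` gives 45% and compound 3 `COC(=O)C(=O)Nc1cccc(C(=O)/C=C/c2ccc(O)c(OC)c2)c1` gives 43%. Compound 4 `CCOC(=O)C(=O)Nc1cccc(C(=O)/C=C/c2ccc(O)c(OC)c2)c1` differs from compound 2 by ethoxycarbonyl in place of isopropyl on a carbonyl carbon. The measured step that bears most directly on this change is a number 13 percentage points lower from compound 2 to compound 3 (beyond the scatter), modest and beyond the scatter; the step of a number 2 percentage points lower from compound 1 to compound 3 (within the scatter) lies within the scatter, so the ester-bearing amide sits near compound 1 rather than compound 2. A modest drop in this assay is therefore expected, of about a number 12 percentage points lower from compound 2 to compound 4 (beyond the scatter). Compound 4 is expected to give 44%, with a range from 30% to 58%.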

Compound 4, a percentage reported as inhibition, at one concentration (the size of the read-out at that concentration, not a potency): 66%
Compound 4: middle estimate off by 22 percentage points, on the low side; measured number above the stated range.
By their numbers in this assay, from the lowest: compounds 3 and 1 (each within the scatter of the next); then compounds 2 and 4 (each within the scatter of the next).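

In this assay, ethoxycarbonyl on a carbonyl carbon bound to the amide-type nitrogen stands level with isopropyl (a number 10 percentage points higher from compound 2 to compound 4 (within the scatter)), so the drop seen with methoxycarbonyl does not extend to every ester-bearing group at this place. One methyl on the ester chain separates the two esters (a number 23 percentage points higher from compound 3 to compound 4 (beyond the scatter)), and ethoxycarbonyl also stands clear of 3,4-dichlorophenyl (a number 21 percentage points higher from compound 1 to compound 4 (beyond the scatter)). No measurement here accounts for the size of the methyl step. Open, from the compounds shown here alone, is whether a longer chain on the ester oxygen, such as propoxycarbonyl, keeps this level. Going by these compounds, a carboxylic acid at this place also remains open.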